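The source may report more compounds than this note shows. Statements on the series, on what has been measured and on what is new or still open speak of the compounds shown alone.

Three compounds share the core of compound 1, whose structure is `COc1cc(C)cc(-c2nn(CC#N)cc2-c2ccc(-c3cccc(C(C)=O)c3)nc2)c1`. In a functional assay on NCI-H23 cells (Homo sapiens) for cytotoxicity, read by sulforhodamine B assay, with a stated time of 48 h, tested at 1 uM (a higher number here means a weaker effect of the compound at the concentration tested, a lower number a stronger effect), compound 1 gives 17%. Compound 2, `Cc1cc(O)cc(-c2nn(CC#N)cc2-c2ccnc(-c3ccc(Oc4ccccc4)cc3)c2)c1`, gives -64% in this assay, and compound 3, `COc1cc(C)cc(-c2nn(CC#N)cc2-c2ccnc(-c3ccc(N(C)C)cc3)c2)c1`, gives 15%. On these numbers compound 3 stands second highest of the three, within the scatter of compound 1 and far above compound 2.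

Compound 4, `Cc1cc(O)cc(-c2nn(CC#N)cc2-c2ccnc(-c3ccc(N(C)C)cc3)c2)c1`, has not yet been measured. It differs from compound 3 in one place: hydrogen in place of methyl on an oxygen on an aromatic ring. Among the compounds with values here, no measured pair shows this change on its own. Compound 2, which also bears the 3-hydroxy-5-methylphenyl group, gives -64%, so compound 4 is expected to move downward by a number 25 percentage points lower from compound 3 to compound 4 (beyond the scatter). Compound 4 is estimated at -10%, with a range from -60% to 25%.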

Compound 4, a percentage reported as activity, at one concentration (the size of the read-out at that concentration, not a potency): 24%
Beside the measured number, compound 4's estimate is 34 percentage points below it, and the stated range covers the measured number.
By their numbers in this assay, from the lowest: compound 2; then compounds 3, 1 and 4 (each within the scatter of the next).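

Hydrogen in place of methyl on the oxygen gives a number 9 percentage points higher from compound 3 to compound 4 (within the scatter) in this assay when the dimethylamino group is present, so at this position methoxy and hydroxy cannot be told apart here. With the hydroxy group held, dimethylamino in place of phenoxy gives a number 88 percentage points higher from compound 2 to compound 4 (beyond the scatter) and thus shows that the hydroxy group alone does not bring the strong effect of compound 2. Nothing shown explains the size of either step. Going by these compounds, whether methoxy and hydroxy also match alongside phenoxy remains open, as does the outcome with an amino or ethoxy group in place of the hydroxy group.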